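Nitro in Place of Ethyl: Expecting Compound 3

A few compounds are considered here, and "the series" means these few. Any claim that something is new, unique, unknown or untested is made for them only; others in the source may bear on it.

Compound 1, `CCc1cccc(NC(=N)Nc2cccc3ccccc23)c1`, gives 54 nM in an assay on membranes from brain (Cavia porcellus) for binding affinity to Sigma non-opioid intracellular receptor 1 (Homo sapiens), read by radioligand binding; on this read-out lower numbers stand for stronger inhibition and higher numbers for weaker inhibition.
Compound 2, `CCc1cccc(NC(=N)N(C)c2cccc3ccccc23)c1`, gives 1000 nM.

Going by the values given here, compound 2 holds the higher of the two numbers; its only neighbour is compound 1, and the single measured step, a 19-fold higher number from compound 1 to compound 2 (1.27 log units; beyond the scatter), concerns a methyl on a nitrogen. Compound 3, `CN(C(=N)Nc1cccc([N+](=O)[O-])c1)c1cccc2ccccc12`, differs from compound 2 by nitro in place of ethyl on an aromatic carbon. Among the compounds with values here, no measured step touches this kind of change, so the data give no direction for it; any shift is expected to stay within the scatter. The expected step is a 1.3-fold higher number from compound 2 to compound 3 (0.11 log units; within the scatter). Compound 3 is estimated at 1300 nM, between 350 nM and 5000 nM in this assay.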

Compound 3, half-maximal inhibitory concentration: 2640 nM
Compound 3: middle estimate off by 2.0-fold (0.31 log units), on the low side; measured number inside the range.
By their numbers in this assay, from the lowest: compound 1; then compound 2; then compound 3.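

In this assay, the aromatic carbon meta to a large group proves responsive: nitro in place of ethyl gives a modest shift (a 2.6-fold higher number from compound 2 to compound 3 (0.42 log units; beyond the scatter)), the first measured direction for a change at this position. That shift is smaller than the one seen on the nitrogen (a 19-fold higher number from compound 1 to compound 2 (1.27 log units; beyond the scatter)). No evidence is available that explains it.

The compounds shown leave open whether nitro in place of ethyl would have a similar effect with hydrogen rather than methyl on the nitrogen. They also leave open how an amine or a methoxy group on this aromatic carbon would compare with ethyl and nitro.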